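A few compounds are considered here, and "the series" means these few. Any claim that something is new, unique, unknown or untested is made for them only; others in the source may bear on it.

Measured in a functional assay on MCF7 cells (Homo sapiens) for cytotoxicity, read by MTT assay, with a stated time of 72 h; on this read-out higher numbers stand for weaker inhibition and lower numbers for stronger inhibition:

Compound 1, `COc1cc(/C=N/NC(=O)Nc2cc3c(Nc4ccc(F)c(Cl)c4)ncnc3cc2O[C@H]2CCOC2)cc(OC)c1OC`, gives 26500 nM.
Compound 2, `O=C(N/N=C/c1ccc(O)c(Br)c1)Nc1cc2c(Nc3ccc(F)c(Cl)c3)ncnc2cc1O[C@H]1CCOC1`, gives 2690 nM.
Compound 3, `O=C(N/N=C/c1ccc(O)cc1O)Nc1cc2c(Nc3ccc(F)c(Cl)c3)ncnc2cc1O[C@H]1CCOC1`, gives 5350 nM.

Compound 3 stands second highest of the three numbers. Its nearest neighbour is compound 2: the step of a 2.0-fold higher number from compound 2 to compound 3 (0.30 log units; within the scatter) lies within the scatter, so the two cannot be told apart. Its furthest is compound 1: the step of a 5.0-fold lower number from compound 1 to compound 3 (0.69 log units; beyond the scatter) lies beyond the scatter.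

Compound 4, `COc1cc2ncnc(Nc3ccc(F)c(Cl)c3)c2cc1NC(=O)N/N=C/c1ccc(O)cc1O`, differs from compound 3 in one place: methyl in place of oxolan-3-yl on an oxygen on an aromatic ring. For the measured compounds named here, every measured step so far changes the ring attached to the carbon with a double bond to nitrogen, namely a 9.9-fold lower number from compound 1 to compound 2 (0.99 log units; beyond the scatter), a 5.0-fold lower number from compound 1 to compound 3 (0.69 log units; beyond the scatter) and a 2.0-fold higher number from compound 2 to compound 3 (0.30 log units; within the scatter). Going by the values given here, none of them touches the oxygen on the aromatic ring, so no measured step bears on this change, and no step beyond the scatter is expected in either direction in this assay. The estimate for compound 4 is therefore 6000 nM, with a range from 1500 nM to 25000 nM, which corresponds to an expected step of a 1.1-fold higher number from compound 3 to compound 4 (0.05 log units; within the scatter).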

Compound 4, half-maximal inhibitory concentration: 36200 nM
For compound 4 the middle estimate is 6.0-fold (0.78 log units) below the measured one, and the stated range ends below it.
By their numbers in this assay, from the lowest: compounds 2 and 3 (each within the scatter of the next); then compounds 1 and 4 (each within the scatter of the next).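

In this assay, replacing (oxolan-3-yl)oxy with methoxy gives a 6.8-fold higher number from compound 3 to compound 4 (0.83 log units; beyond the scatter). For the compounds shown here, this is the first change on an oxygen on an aromatic ring, and it shows that this position also affects the result, with methyl giving weaker inhibition than oxolan-3-yl. The swap removes a five-membered non-aromatic ring, a hydrogen-bond acceptor and a defined stereocentre together, and no measurement available here gives the reason for this step.

Going by these compounds alone, this position is seen with only two groups and only with 2,4-dihydroxyphenyl on the carbon with a double bond to nitrogen, so it is open whether the same step would appear with 3-bromo-4-hydroxyphenyl. Also open, from the compounds shown here alone, is whether a 2-methoxyethyl chain or an amine such as a morpholinylpropyl chain would behave more like oxolan-3-yl or like methyl.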